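Estimating Compound 4 Without a Number for Compound 3

The source may report more compounds than this note shows. Statements on the series, on what has been measured and on what is new or still open speak of the compounds shown alone.

In a functional assay on A2780 cells (Homo sapiens) for antiproliferative activity (on this read-out lower numbers stand for stronger inhibition and higher numbers for weaker inhibition), compound 1 (`Cc1ccc2c(c1C)CN(C(C)C)CC2c1ccccc1`) gives 6280 nM and compound 2 (`Cc1ccc2c(c1C)CN(CCCN(C)C)CC2c1ccccc1`) gives 3240 nM on a shared core. Compound 3 (`Cc1ccc2c(c1C)CN(C(N)=O)CC2c1ccccc1`) carries the entry "not determined" (no result reported) there, so it offers no number to start from. Compound 4 (`Cc1ccc2c(c1C)CN(C(=O)N(C)C)CC2c1ccccc1`) has not yet been measured. It differs from compound 3 in one place, with dimethylamino in place of amino on a carbonyl carbon, and the count of that change reads dimethylamino in place of amino on a carbonyl carbon in full.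

Within the data shown here, the only measured step is a 1.9-fold lower number from compound 1 to compound 2 (0.29 log units; within the scatter) and it lies within the scatter. That step swaps isopropyl for 3-(dimethylamino)propyl on an amine nitrogen in a ring, which is not the change at hand, so it is only loose guidance. With no number for compound 3, no size or direction can be given for the step to compound 4. Among the measured compounds shown here, the data show only that compound 1 at 6280 nM and compound 2 at 3240 nM sit within the scatter of each other, and compound 4 shares their core. Compound 4 is therefore expected at about 5000 nM in the estimate, with a wide range from 1500 nM to 15000 nM expected.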

Compound 4, half-maximal inhibitory concentration: 1200 nM
Estimate against measurement, compound 4: 4.2-fold (0.62 log units) above; the whole stated range lies above it.
By their numbers in this assay, from the lowest: compound 4; then compounds 2 and 1 (each within the scatter of the next).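

In this assay, dimethylcarbamoyl in place of 3-(dimethylamino)propyl on an amine nitrogen in a ring gives a 2.7-fold lower number from compound 2 to compound 4 (0.43 log units; beyond the scatter) and dimethylcarbamoyl in place of isopropyl on that nitrogen gives a 5.2-fold lower number from compound 1 to compound 4 (0.72 log units; beyond the scatter) and these two modest steps put compound 4 lowest of the three compounds with a number. Among these compounds, the earlier change on this nitrogen gave only a 1.9-fold lower number from compound 1 to compound 2 (0.29 log units; within the scatter) so the new steps are the first here to go beyond the scatter, which means the read-out can respond to what sits at this position. Nothing shown gives a reason for these differences.

Going by these compounds, compound 3 has no reported number, so the step from it to compound 4 cannot be read, and the effect of dimethylamino in place of amino on a carbonyl carbon remains unknown. On these data alone, it also remains open how an acetyl group or a diethylcarbamoyl group on the same nitrogen would compare with the dimethylcarbamoyl group of compound 4, and whether the drop seen here would extend to such neighbouring groups.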